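Swapping the ring nitrogen substituent of a pyrazolopyrimidine sulfonamide

The source may report more compounds than this note shows. Statements on the series, on what has been measured and on what is new or still open speak of the compounds shown alone.

Of the compounds shown here, two sharing a dichlorophenylsulfonamide have been measured in a functional assay on cells for antagonist activity at C-C chemokine receptor type 4 (Homo sapiens), read by GTPgammaS binding; a higher number here means a weaker inhibitor, a lower number a stronger inhibitor. Compound 1 `Cn1ncc2c(NS(=O)(=O)c3cccc(Cl)c3Cl)cccc21` gives 3160 nM. Compound 2 `COc1nn(C(C)C)c2ncnc(NS(=O)(=O)c3cccc(Cl)c3Cl)c12` gives 251 nM, the lowest of the two numbers, and its distance from compound 1 lies beyond the scatter of repeated measurements in this assay. Compound 3 `COc1nn(CCN(C)C)c2ncnc(NS(=O)(=O)c3cccc(Cl)c3Cl)c12` has not been measured; it differs from compound 2 in one place: 2-(dimethylamino)ethyl in place of isopropyl on an aromatic nitrogen. Among the compounds with values here, no measured pair shows a step of this kind, so the size of the effect in this assay is unknown from the data at hand. The step from compound 2 to compound 3 is estimated to be small, within or close to the usual scatter, with no clear direction a 1.6-fold higher number from compound 2 to compound 3 (0.20 log units; within the scatter). For compound 3 the expected value in this assay is 400 nM, with a range from 100 nM to 1600 nM.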

Compound 3, half-maximal inhibitory concentration: 3980 nM
Compound 3: the middle estimate sits 10-fold (1.00 log units) below what was measured; measured number outside the range, above it.
By their numbers in this assay, from the lowest: compound 2; then compounds 1 and 3 (each within the scatter of the next).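

In this assay, placing 2-(dimethylamino)ethyl in place of isopropyl on an aromatic nitrogen gives a 16-fold higher number from compound 2 to compound 3 (1.20 log units; beyond the scatter) and so makes compound 3 a clearly weaker inhibitor than compound 2. Within the data shown here, this is the first one-place comparison at this nitrogen, and it shows that the substituent there can strongly change the result rather than being freely exchangeable. No accompanying measurement accounts for the size of this step.

The compounds shown do not separate the effect of the longer chain from that of its amine nitrogen; a plain n-butyl chain or a 2-methoxyethyl group at this nitrogen would bear on that question. They also leave open whether a smaller methyl group or a carboxylic acid on a chain would be tolerated here.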